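The compounds below may be only part of what the source reports. "The series", "measured", "known", "first", "only" and "open" are said of these compounds alone.

Working notes on the series. Compound 1 `OC[C@H]1O[C@@H](n2cnc3c(NCc4ccc(Br)cc4)ncnc32)[C@H](O)[C@@H]1O` carries a 4-bromophenyl on the saturated chain carbon bound to a nitrogen on the aromatic ring. In a functional assay on HOS cells (Homo sapiens) for antiproliferative activity, with a stated time of 72 h (on this read-out higher numbers stand for weaker inhibition and lower numbers for stronger inhibition), compound 1 returns only a limit, > 166000 nM. Compound 2 `COc1ccccc1CNc1ncnc2c1ncn2[C@@H]1O[C@H](CO)[C@@H](O)[C@H]1O` differs by a 2-methoxyphenyl in the same place. In this assay compound 2 likewise returns only a limit, > 166000 nM. Among the compounds with values here, the step that the two limits leave unreadable from compound 1 to compound 2 is therefore not readable, since both ends sit at the limit; this is the sole measured step, and the evidence on it is the limit itself, (the limit of > 166000 nM in this assay, at which 2 of the 3 values shown sit). Compound 3 `OC[C@H]1O[C@@H](n2cnc3c(NCc4cc(F)cc(F)c4)ncnc32)C(O)C1O` carries a 3,5-difluorophenyl; for compound 3 the result in this assay is "not determined" (no result reported).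

Where compound 2 stands: at the limit, alongside compound 1, with no single number for any compound.

The next compound, compound 4 `OC[C@H]1O[C@@H](n2cnc3c(NCc4ccc(F)cc4Cl)ncnc32)[C@H](O)[C@@H]1O`, differs from compound 2 by 2-chloro-4-fluorophenyl in place of 2-methoxyphenyl on a saturated chain carbon bound to a nitrogen on an aromatic ring. Within the data shown here, no measured step bears on this change with a readable size. Given that compound 2 sits at the limit > 166000 nM, and that compound 1 sits at the same limit, the expectation for compound 4 is no change beyond the scatter, the step that the limit leaves unreadable from compound 2 to compound 4 being the estimate. Compound 4 is thus expected at 200000 nM, within 100000 nM to 400000 nM, most likely again as a limit.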

Compound 4, half-maximal inhibitory concentration: > 166000 nM
Compound 4 gave a limit, no number (the forecaster's own chance of this, stated with the estimate: 85%); the middle value lies beyond the limit too.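

Compound 4 also returns only a limit in this assay and not a number, so no step among compound 1, compound 2 and compound 4 can be read: the limit of > 166000 nM in this assay, at which 3 of the 4 values shown sit.

The compounds shown leave open whether any group at this place on the saturated chain carbon gives a single number, and how large any step there is.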